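Adding Fluorine to a Weak Inhibitor

This account rests on a few compounds, and the source may have more. Where it says the series, first, only, none or still open, it means among the compounds named here.

Measured so far:
Compound 1, `CC1(CO)OCC(n2cc(F)c(N)nc2=O)O1`, gives in a functional assay on B16-F10 cells (Mus musculus) for inhibition (a lower number here means a stronger inhibitor, a higher number a weaker inhibitor), the value > 100000 nM, which is a limit of the assay and not a number.
Compound 2, `C[C@]1(CO)OCC(n2ccc(N)nc2=O)O1`, gives in this assay the value 100000 nM.

In this assay, within the data shown here, compound 2 stands as the only compound with an actual number; the one other result is a limit. The other result measured here therefore sits at the limit of > 100000 nM in this assay, at which 1 of the 2 values shown sits, and compound 2 itself is a weak inhibitor.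

Compound 3, `C[C@]1(CO)OCC(n2cc(F)c(N)nc2=O)O1`, has not yet been tested. It differs from compound 2 in one place: fluoro in place of hydrogen on an aromatic carbon. Among the measured compounds shown here, no step between two measured compounds is available, so the size of this change cannot be read off; it has to be expected. Compound 1, which also carries the fluoro group, gave only the limit > 100000 nM. With that in mind, the expected change is no change at the digits printed from compound 2 to compound 3 (within the scatter), meaning nothing beyond the scatter, with a real chance that only a limit is reported. Compound 3 is estimated at 100000 nM, in a range from 30000 nM to 300000 nM.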

Compound 3, half-maximal inhibitory concentration: > 100000 nM
Compound 3: no number, only a limit (the forecaster's own chance of this, stated with the estimate: 60%); the middle value sits exactly at the limit.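

In this assay, fluoro in place of hydrogen on this aromatic carbon, ortho to an amino group, brings no gain in inhibition: the result is a number no lower from compound 2 to compound 3 (the limit leaves the size open). Compound 3 gives > 100000 nM, which is a limit of the assay and not a number. Both compounds that carry fluoro now end at the edge of what this assay can report, so the set has little room to separate them: the limit of > 100000 nM in this assay, at which 2 of the 3 values shown sit.

Among these compounds, how far compound 3 really lies from compound 2 stays open, and so does any role of the drawn configuration, as neither of the steps to compound 3 can be read in size: the fact that one of compounds 1 and 3 is drawn with a defined configuration and the other without, at the place where they differ Also open is whether a different group on this aromatic carbon, such as chloro, methyl or an amine, would give a number lower than the one for compound 2.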